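Series notes: expected permeability of compound 4

This account rests on a few compounds, and the source may have more. Where it says the series, first, only, none or still open, it means among the compounds named here.

Compound 2 `FC(F)(F)c1ccc(-c2ccc3c(NCCCNCc4ccco4)ccnc3c2)cc1` sits level with both neighbours in an ADME assay for permeability, using PAMPA, with a stated time of 30 min, at pH 7.4; a lower number here means that the compound crosses the layer more slowly, a higher number that the compound crosses the layer faster: compound 2 gives 237 10^-6 cm/s, compound 1 `COc1cccc(CNCCCNc2ccnc3cc(-c4ccc(C(F)(F)F)cc4)ccc23)c1O` gives 237 10^-6 cm/s and compound 3 `COc1ccc(F)cc1CNCCCNc1ccnc2cc(-c3ccccc3)ccc12` gives 237 10^-6 cm/s. Within the data shown here, the single measured step, no change at the digits printed from compound 1 to compound 2 (within the scatter), exchanged the group on the saturated chain carbon bound to the amine nitrogen and left the number where it was. Compound 4 `N#Cc1ccc(Cc2ccc3c(NCCCNCc4ccco4)ccnc3c2)cc1` differs from compound 2 at the other end of the shared core: 4-cyanobenzyl in place of 4-(trifluoromethyl)phenyl on an aromatic carbon. Among the measured compounds shown here, no measured step touches that aromatic carbon, so the measured step bears on it only indirectly, by showing that one exchange of a terminal group left this assay unmoved. With all three measured compounds at one value and nothing pointing another way, compound 4 is expected to stay near that level, the step of a 1.2-fold lower number from compound 2 to compound 4 (0.07 log units; within the scatter) being estimated as none beyond the scatter, with a small downward lean allowed for. Compound 4 is estimated at 200 10^-6 cm/s, with a range from 100 10^-6 cm/s to 320 10^-6 cm/s.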

Compound 4, apparent permeability: 23 10^-6 cm/s
Beside the measured number, compound 4's estimate is 8.7-fold (0.94 log units) above it, and the stated range ends above it.
By their numbers in this assay, from the lowest: compound 4; then compounds 1, 2 and 3 (each within the scatter of the next).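

In this assay, among these compounds, the aromatic carbon carrying this group is the first place where an exchange moves the number: a 10-fold lower number from compound 2 to compound 4 (1.01 log units; beyond the scatter), whereas the exchange on the saturated chain carbon, no change at the digits printed from compound 1 to compound 2 (within the scatter), left it level. Among the compounds shown here, the level values of the earlier compounds therefore do not carry over to this position, where one exchange changes two things together: a 4-substituted phenyl becomes a 4-substituted benzyl, and trifluoromethyl gives way to a nitrile carrying 1 hydrogen-bond acceptor. Nothing available explains the drop.

The compounds shown leave open which of these two changes goes with the lower number. A 4-cyanophenyl or a 4-(trifluoromethyl)benzyl on the same aromatic carbon would separate them.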